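Triazole-linked terpenoid series: estimate for the pyridyl analogue

This account rests on a few compounds, and the source may have more. Where it says the series, first, only, none or still open, it means among the compounds named here.

Measured so far in a functional assay on MCF7 cells (Homo sapiens) for cytotoxicity, read by MTT assay, with a stated time of 48 h; a lower number here means a stronger inhibitor, a higher number a weaker inhibitor:
- compound 1 `CC(C)=CCC/C(C)=C/CC/C(C)=C/CC[C@@H]1[C@@]2(C)CCC(=O)C(C)(C)[C@@H]2CC[C@@]1(C)O`: 16200 nM
- compound 2 `CC(C)=CCC/C(C)=C/CC/C(C)=C/CC[C@@H]1[C@@]2(C)CC/C(=N\OCc3cn(-c4ccccc4C#N)nn3)C(C)(C)[C@@H]2CC[C@@]1(C)O`: 24900 nM
- compound 3 `CC(C)=CCC/C(C)=C/CC/C(C)=C/CC[C@@H]1[C@@]2(C)C/C(=C\c3ccc(OCc4cn(-c5ccccc5)nn4)cc3)C(=O)C(C)(C)[C@@H]2CC[C@@]1(C)O`: 23000 nM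

The three measured compounds share the same core and differ in what is attached at the ketone or at the carbon next to it. In this assay compound 3 stands second highest of the three numbers; its nearest neighbour is compound 2 and its furthest is compound 1, and both gaps lie within the scatter, so no order among the three can be read from these values.

Compound 4 `CC(C)=CCC/C(C)=C/CC/C(C)=C/CC[C@@H]1[C@@]2(C)C/C(=C\c3ccc(OCc4cn(-c5ccncc5)nn4)cc3)C(=O)C(C)(C)[C@@H]2CC[C@@]1(C)O` is the next member. It differs from compound 3 in one place: pyridin-4-yl in place of phenyl on an aromatic nitrogen. Among the measured compounds shown here, no step between measured compounds of this kind is available, so there is nothing to size this change by.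

Given that the other changes seen so far stayed within the scatter, the step from compound 3 to compound 4 is expected to be small, no change at the digits printed from compound 3 to compound 4 (within the scatter), with no direction preferred. Compound 4 is therefore estimated at 23000 nM in this assay, with a likely range from 11000 nM to 48000 nM.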

Compound 4, half-maximal inhibitory concentration: 37500 nM
Estimate against measurement, compound 4: 1.6-fold (0.21 log units) below, within the range that was stated.
By their numbers in this assay, from the lowest: compounds 1, 3, 2 and 4 (each within the scatter of the next, the first and the last beyond it).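

This position on an aromatic nitrogen of the five-membered aromatic ring with 3 nitrogen now has its first measured step: in this assay, pyridin-4-yl in place of phenyl gives a 1.6-fold higher number from compound 3 to compound 4 (0.21 log units; within the scatter). With the step inside the scatter, the swap of one ring carbon for a ring nitrogen, which brings in a hydrogen-bond acceptor, is not shown to shift the number in either direction at this position. Nothing available bears on what lies behind the size of this step.

It remains open whether pyridin-2-yl or pyridin-3-yl at the same position would give a similar result, since only the pyridin-4-yl isomer is shown. Also open, from the compounds shown here alone, is whether a group carrying an amine or a carboxylic acid in place of phenyl would produce a step beyond the scatter.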